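Chloro to Methyl on the Benzyl Arm of Compound 2

A few compounds are considered here, and "the series" means these few. Any claim that something is new, unique, unknown or untested is made for them only; others in the source may bear on it.

Two compounds have been measured:
Compound 1, `C#CCOc1cc(O)c2c(c1)O[C@H](c1ccc(OC)c(O)c1)C/C2=N\O`, gives 19100 nM in a functional assay on RAW264.7 cells (Mus musculus) for inhibition, read by Griess assay, with stated times of 2 h and 24 h; on this read-out lower numbers stand for stronger inhibition and higher numbers for weaker inhibition.
Compound 2, `COc1ccc([C@@H]2CC(=O)c3c(O)cc(OCc4cn(Cc5cccc(Cl)c5)nn4)cc3O2)cc1O`, gives 18200 nM in this assay.

Among the compounds with values here, on these numbers compound 2 has the lower of the two values, but its only neighbour, compound 1, sits so close that the two cannot be told apart; the difference between them lies within the usual scatter of repeated measurements, so neither compound can be called the stronger inhibitor.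

Compound 3, `COc1ccc([C@@H]2CC(=O)c3c(O)cc(OCc4cn(Cc5cccc(C)c5)nn4)cc3O2)cc1O`, is not yet measured. It differs from compound 2 in one place only: methyl in place of chloro on an aromatic carbon. The chloro group leaves and a methyl group enters on the same aromatic carbon of the six-membered carbon ring, meta to a large group.

Within the data shown here, no pair of measured compounds differing in a single place is available here, so there is no measured step to lean on for this kind of change. Given that, compound 3 is expected to stay near compound 2, and the step from compound 2 to compound 3 is estimated at a 1.0-fold lower number from compound 2 to compound 3 (0.00 log units; within the scatter), that is, no change beyond the scatter in either direction. Compound 3 is therefore estimated at 18000 nM, with a range from 7000 nM to 45000 nM.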

Compound 3, half-maximal inhibitory concentration: 17400 nM
Estimate against measurement, compound 3: 1.0-fold (0.01 log units) above; the range from low to high includes it.
By their numbers in this assay, from the lowest: compounds 3, 2 and 1 (each within the scatter of the next).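

Within the data shown here, this pair gives the first direct reading of a single change: putting methyl in place of chloro on the aromatic carbon meta to a large group, which turns the 3-chlorobenzyl arm into a 3-methylbenzyl arm, gives a 1.0-fold lower number from compound 2 to compound 3 (0.02 log units; within the scatter) in this assay. The two compounds therefore cannot be told apart on this read-out, and at this position chloro and methyl are interchangeable as far as this one pair can show. No other measurement here bears on this result, so the data give no explanation for why the two groups read alike.

From the compounds shown here alone, one pair with one swap says little about the position as a whole, and it remains open whether an amine, a carboxylic acid or a longer chain on the same aromatic carbon would also read like chloro and methyl or would move the number beyond the scatter. Going by these compounds, it also remains open whether the same swap of chloro for methyl would give a similar result on another scaffold or in a different assay.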